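Aryl sulfanyl variation on the shared nucleoside core

This account rests on a few compounds, and the source may have more. Where it says the series, first, only, none or still open, it means among the compounds named here.

Among the three measured compounds, compound 3 `OC[C@H]1O[C@@H](n2cnc3c(CSc4ccccc4Br)ncnc32)[C@H](O)[C@@H]1O` stands second highest in an assay on isolated protein for binding affinity to Equilibrative nucleoside transporter 1 (Homo sapiens) (on this read-out higher numbers stand for weaker inhibition and lower numbers for stronger inhibition), giving 2400 nM; compound 1 `OC[C@H]1O[C@@H](n2cnc3c(SCC4CCCCC4)ncnc32)[C@H](O)[C@@H]1O` gives 1550 nM and compound 2 `CCSc1ncnc2c1ncn2[C@@H]1O[C@H](CO)[C@@H](O)[C@H]1O` gives 57500 nM. The step of a 1.5-fold higher number from compound 1 to compound 3 (0.19 log units; within the scatter) lies within the scatter, whereas a 24-fold lower number from compound 2 to compound 3 (1.38 log units; beyond the scatter) is large, as is a 37-fold higher number from compound 1 to compound 2 (1.57 log units; beyond the scatter). Compound 4 `N#Cc1ccc(SCc2ncnc3c2ncn3[C@@H]2O[C@H](CO)[C@@H](O)[C@H]2O)cc1` differs from compound 3 by 4-cyanophenyl in place of 2-bromophenyl on a sulfur. Among the compounds with values here, no measured step exchanges one aryl group for another, so the change is only bracketed indirectly: the two steps that reach compound 3 show that a (cyclohexylmethyl)sulfanyl group and a ((2-bromophenyl)sulfanyl)methyl group give numbers within the scatter of each other, while an ethylsulfanyl group gives a far higher number. Another aryl ring on the same sulfur is therefore expected to land near compound 3, with no step beyond the scatter anticipated, the estimated step being no change at the digits printed from compound 3 to compound 4 (within the scatter). For compound 4 the expected value in this assay is 2400 nM, with a range from 800 nM to 7000 nM.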

Compound 4, half-maximal inhibitory concentration: 81.3 nM
Estimate against measurement, compound 4: 30-fold (1.47 log units) above, outside the stated range (below it).
By their numbers in this assay, from the lowest: compound 4; then compounds 1 and 3 (each within the scatter of the next); then compound 2.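

In this assay, 4-cyanophenyl in place of 2-bromophenyl on the sulfur gives a 30-fold lower number from compound 3 to compound 4 (1.47 log units; beyond the scatter), so the number at this position depends strongly on the aryl group itself and not only on an aryl group being present. The earlier steps shown here exchanged whole side chains, and the values of compound 1 and compound 3, within the scatter of each other, gave no sign of this sensitivity. Nothing shown gives a reason for the size of this step.

The step changes both the substituent and its place on the ring, and a 4-bromophenyl or 2-cyanophenyl group on the same sulfur would separate these two changes. Also open, going by these compounds, is whether other groups at the 4-position of the ring, such as methoxy or a carboxylic acid, keep a number as low as that of compound 4.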